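This account rests on a few compounds, and the source may have more. Where it says the series, first, only, none or still open, it means among the compounds named here.

Compound 1 `O=C(CCl)N1CCCC(n2nc(-c3ccc(Oc4ccccc4)cc3)cc2CO)C1`: 400 nM
Compound 2 `O=C(CCl)Nc1cccc(Cn2nc(-c3ccc(Oc4ccccc4)cc3)cc2CO)c1`: 400 nM
Compound 3 `CCOC(=O)c1cc(-c2ccc(Oc3ccccc3)cc2)nn1Cc1cccc(NC(=O)CCl)c1`: 400 nM

In a functional assay on Rec1 cells (Homo sapiens) for inhibition, read by luminescence and CellTiter-Glo, with a stated time of 72 h (a lower number here means a stronger inhibitor, a higher number a weaker inhibitor), compound 3 stands level with compounds 1 and 2 at the digits shown: compound 1 is nearest and compound 2 furthest, yet both gaps lie within the scatter. Among the measured compounds shown here, the one single-point step measured so far, no change at the digits printed from compound 2 to compound 3 (within the scatter), concerns a different part of the molecule. Compound 4 `CCOC(=O)c1cc(-c2ccc(Oc3ccccc3)cc2)nn1Cc1ccc(NC(=O)CCl)cc1` differs from compound 3 by 4-(((chloromethyl)carbonyl)amino)phenyl in place of 3-(((chloromethyl)carbonyl)amino)phenyl on a saturated chain carbon bound to an aromatic nitrogen. No measured step moves this group around its ring, so the data give no reason to expect a shift beyond the scatter in either direction. Compound 4 is therefore expected to give 400 nM, with a range from 200 nM to 800 nM. This estimate means a step of no change at the digits printed from compound 3 to compound 4 (within the scatter), within the scatter.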

Compound 4, half-maximal inhibitory concentration: 400 nM
For compound 4 middle estimate and measured number coincide at the digits printed; measured number inside the range.
By their numbers in this assay, from the lowest: compounds 1, 2, 3 and 4 (each within the scatter of the next).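

In this assay, 4-(((chloromethyl)carbonyl)amino)phenyl in place of 3-(((chloromethyl)carbonyl)amino)phenyl gives no change at the digits printed from compound 3 to compound 4 (within the scatter) on a saturated chain carbon bound to an aromatic nitrogen. This first measured change to this group shows that, with ethoxycarbonyl on the shared core, the two attachment patterns cannot be told apart by this read-out. No measured evidence offers an explanation for this result. From the compounds shown here alone, it remains open whether the same holds with hydroxymethyl in place of ethoxycarbonyl. Also open, going by these compounds, is what a carboxylic acid in that place, or an acetyl group in place of the (chloromethyl)carbonyl, would do.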